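This account rests on a few compounds, and the source may have more. Where it says the series, first, only, none or still open, it means among the compounds named here.

Three measured compounds share one core and differ only in the aryl group attached to it. Compound 1 `COc1cc(-n2cnc3ccc(-c4ccc(Cl)cc4)cc32)cc(OC)c1OC` carries a 4-chlorophenyl group; in a functional assay on A549 cells (Homo sapiens) for antiproliferative activity, read by MTT assay, with a stated time of 72 h (a lower number here means a stronger inhibitor, a higher number a weaker inhibitor), compound 1 gives > 10000 nM, which is a limit of the assay rather than a number (the limit of > 10000 nM in this assay, at which 1 of the 3 values shown sits). Compound 2 `COc1cccc(-c2ccc3ncn(-c4cc(OC)c(OC)c(OC)c4)c3c2)c1` carries a 3-methoxyphenyl group, and in this assay compound 2 gives 3180 nM. Compound 3 `COc1cc(-n2cnc3ccc(-c4ccc(O)cc4)cc32)cc(OC)c1OC` carries a 4-hydroxyphenyl group, and in this assay compound 3 gives 5090 nM. Of the two numbers that are not limits, compound 3 has the higher one, and the step of a 1.6-fold higher number from compound 2 to compound 3 (0.20 log units; within the scatter) lies within the scatter. The step of an at least 1.9-fold lower number from compound 1 to compound 3 (0.29 log units; that floor lies within the scatter) has a floor that also lies within the scatter, whereas an at least 3.1-fold lower number from compound 1 to compound 2 (0.49 log units; beyond the scatter) is at least modest.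

Compound 4 `CCOc1ccc(-c2ccc3ncn(-c4cc(OC)c(OC)c(OC)c4)c3c2)cc1` differs from compound 3 by ethyl in place of hydrogen on an oxygen on an aromatic ring. Among the compounds with values here, no measured step adds an alkyl onto the hydroxy group; the nearest comparisons, a 1.6-fold higher number from compound 2 to compound 3 (0.20 log units; within the scatter) and an at least 1.9-fold lower number from compound 1 to compound 3 (0.29 log units; that floor lies within the scatter), exchange the ring substituent entirely and stay within the scatter. He therefore expects no step beyond the scatter in this assay and estimates a change of a 1.3-fold lower number from compound 3 to compound 4 (0.10 log units; within the scatter). Compound 4 is estimated at 4000 nM, with a range from 1500 nM to 12000 nM.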

Compound 4, half-maximal inhibitory concentration: 8550 nM
Beside the measured number, compound 4's estimate is 2.1-fold (0.33 log units) below it; the range from low to high includes it.
By their numbers in this assay, from the lowest: compounds 2, 3 and 4 (each within the scatter of the next, the first and the last beyond it). At a limit, above all of these: compound 1.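

In this assay, within the data shown here, the one step confined to this oxygen on an aromatic ring, hydroxy to ethoxy, is a 1.7-fold higher number from compound 3 to compound 4 (0.23 log units; within the scatter) and so stays within the scatter, which means that replacing the hydrogen with ethyl neither clearly gains nor clearly loses activity here. The new compound does separate two aryl groups, since a 2.7-fold higher number from compound 2 to compound 4 (0.43 log units; beyond the scatter) is a modest step beyond the scatter between 4-ethoxyphenyl and 3-methoxyphenyl, even though compound 3 lies within the scatter of both compound 2 and compound 4. The remaining step, an at least 1.1-fold lower number from compound 1 to compound 4 (0.06 log units; that floor lies within the scatter), gives only a floor within the scatter and cannot be read as a real difference, with compound 1 still standing at a limit of the assay: the limit of > 10000 nM in this assay, at which 1 of the 4 values shown sits.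

The compounds shown leave open whether a longer chain on this oxygen, such as butoxy, would carry the trend further or whether the ethoxy result is specific to ethyl. They also leave open how an amine or a carboxylic acid in place of the hydroxy group would fare in this assay on the same core.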